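Sulfur for Oxygen on a Cyclohexyl Side Chain

The source may report more compounds than this note shows. Statements on the series, on what has been measured and on what is new or still open speak of the compounds shown alone.

Compound 3 `O=C(NC1CCCCC1)OC[C@H]1OC(n2cnc3c(NC4CCOC4)ncnc32)[C@H](O)[C@@H]1O` is the weakest binder among the three measured compounds. In an assay on DDT1 cells (Cricetulus griseus) for binding affinity to adenosine receptor A1 (Homo sapiens), read by radioligand binding (a higher number here means a weaker inhibitor, a lower number a stronger inhibitor), compound 3 gives 584 nM, whereas compound 1 `C/N=C(\S)OC[C@H]1OC(n2cnc3c(NC4CCOC4)ncnc32)[C@H](O)[C@@H]1O` gives 45 nM and compound 2 `CC(C)/N=C(\S)OC[C@H]1OC(n2cnc3c(NC4CCOC4)ncnc32)[C@H](O)[C@@H]1O` gives 36 nM. Compound 4 `O[C@@H]1[C@@H](CO/C(S)=N/C2CCCCC2)OC(n2cnc3c(NC4CCOC4)ncnc32)[C@@H]1O` differs from compound 3 in one place: a group of 9 heavy atoms (7 carbon, 1 nitrogen, 1 sulfur; one six-membered non-aromatic ring of carbon only) in place of a group of 9 heavy atoms (7 carbon, 1 nitrogen, 1 oxygen; one six-membered non-aromatic ring of carbon only), on an oxygen on a saturated carbon. Within the data shown here, two measured steps bear on this change: a 13-fold higher number from compound 1 to compound 3 (1.11 log units; beyond the scatter) and a 16-fold higher number from compound 2 to compound 3 (1.21 log units; beyond the scatter), both large, while a 1.3-fold lower number from compound 1 to compound 2 (0.10 log units; within the scatter), so the group on the double-bonded nitrogen mattered little there. Compound 4 keeps the sulfur of compounds 1 and 2 while carrying the cyclohexyl ring of compound 3. The step to compound 4 is therefore expected to recover much of that ground, a 9.7-fold lower number from compound 3 to compound 4 (0.99 log units; beyond the scatter). Compound 4 is estimated at about 60 nM, within 25 nM to 150 nM.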

Compound 4, inhibition constant: 253 nM
Compound 4: the middle estimate sits 4.2-fold (0.62 log units) below what was measured, and the stated range ends below it.
By their numbers in this assay, from the lowest: compounds 2 and 1 (each within the scatter of the next); then compound 4; then compound 3.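

On the cyclohexyl side chain, sulfur in place of oxygen is worth only a 2.3-fold lower number from compound 3 to compound 4 (0.36 log units; beyond the scatter) in this assay and does not by itself bring back the binding seen with the methyl and isopropyl groups. The ring also carries a cost, with a 7.0-fold higher number from compound 2 to compound 4 (0.85 log units; beyond the scatter) and a 5.6-fold higher number from compound 1 to compound 4 (0.75 log units; beyond the scatter) for cyclohexyl on the double-bonded nitrogen, so this position does respond to its group even though methyl and isopropyl stayed within the scatter. Nothing measured here gives a reason for these steps.

On these data alone, whether a tert-butyl group already brings this loss, and whether a flat phenyl ring on that nitrogen behaves like cyclohexyl, stays open.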